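This account rests on a few compounds, and the source may have more. Where it says the series, first, only, none or still open, it means among the compounds named here.

Measured compounds:
- compound 1 `CC(C)=CCC/C(C)=C/CC1Cc2c(OCC=C(C)C)cc(=O)n(CCCO)c2CC1(C)C`: 15.9%
- compound 2 `CC(C)=CCC/C(C)=C/COc1cc(=O)n(CCCO)c2c1CC(C/C=C(\C)CCC=C(C)C)C(C)(C)C2`: 3.1%
- compound 3 `COc1cccc(NC(=O)Oc2cc(=O)n(CCCO)c3c2CC(C/C=C(\C)CCC=C(C)C)C(C)(C)C3)c1`: 11.3%

In a functional assay on PANC-1 cells (Homo sapiens) for inhibition, read by MTT assay, with a stated time of 24 h, tested at 10 uM (a higher number here means more inhibition at the concentration tested (going by the name of the read-out), a lower number less inhibition), compound 1 gives 15.9%, compound 2 gives 3.1% and compound 3 gives 11.3%. Compound 3 stands second highest of these three numbers, and both of its neighbours lie within the scatter: a number 4.6 percentage points lower from compound 1 to compound 3 (within the scatter), and a number 8.2 percentage points higher from compound 2 to compound 3 (within the scatter). Among the measured compounds shown here, the only step beyond the scatter is elsewhere, a number 12.8 percentage points lower from compound 1 to compound 2 (beyond the scatter), which concerns a chain carbon rather than the group on the ring oxygen.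

Compound 4 `CC(C)=CCC/C(C)=C/CC1Cc2c(OC(=O)Nc3ccccc3F)cc(=O)n(CCCO)c2CC1(C)C` differs from compound 3 in one place: 2-fluorophenyl in place of 3-methoxyphenyl on an amide-type nitrogen. For the measured compounds named here, no measured step touches this position; the two steps that do involve the ring oxygen, from compound 1 and from compound 2 to compound 3, stayed within the scatter. With nothing pointing either way, compound 4 is expected to sit close to compound 3, with an estimated step of a number 0.3 percentage points lower from compound 3 to compound 4 (within the scatter). Compound 4 is therefore estimated at 11% in this assay, likely between 1% and 22%.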

Compound 4, a percentage reported as inhibition, at one concentration (the size of the read-out at that concentration, not a potency): 0%
For compound 4 the middle estimate is 11 percentage points above the measured one; the whole stated range lies above it.
By their numbers in this assay, from the lowest: compounds 4, 2, 3 and 1 (each within the scatter of the next, the first and the last beyond it).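

Among the compounds shown here, on the amide-type nitrogen, the group is not interchangeable in this assay: 2-fluorophenyl in place of 3-methoxyphenyl gives a number 11.3 percentage points lower from compound 3 to compound 4 (beyond the scatter) and so opens a position that no earlier step had touched. The carbamate on the ring oxygen also reads differently with this group: replacing 3-methylbut-2-en-1-yl gives a number 15.9 percentage points lower from compound 1 to compound 4 (beyond the scatter), whereas replacing 3,7-dimethylocta-2,6-dien-1-yl gives a number 3.1 percentage points lower from compound 2 to compound 4 (within the scatter) on the other ether-bearing comparison. Nothing measured here explains the size of the change at the nitrogen.

The compounds shown leave open whether the fluorine, the loss of the methoxy group or the place of either on the phenyl ring drives this step. Plain phenyl, 3-fluorophenyl and 2-methoxyphenyl on the same nitrogen would separate these three readings.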